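A few compounds are considered here, and "the series" means these few. Any claim that something is new, unique, unknown or untested is made for them only; others in the source may bear on it.

Three compounds have been measured in a functional assay on PC-3 cells (Homo sapiens) for cytotoxicity, read by MTT assay, with a stated time of 72 h; a higher number here means a weaker inhibitor, a lower number a stronger inhibitor:

Compound 1, `FC(F)(F)c1ccc(CSc2nc(Nc3ccccc3)c3ccccc3n2)cc1`: 20000 nM
Compound 2, `Cc1ccccc1Nc1nc(SCc2ccc(C(F)(F)F)cc2)nc2ccccc12`: 36900 nM
Compound 3, `O=[N+]([O-])c1ccc(Nc2nc(SCc3ccc(C(F)(F)F)cc3)nc3ccccc23)cc1`: 7900 nM

Compound 3 gives the lowest of the three numbers, and its steps from both others lie beyond the scatter. Compound 4, `COc1ccc(Nc2nc(SCc3ccc(C(F)(F)F)cc3)nc3ccccc23)cc1`, differs from compound 3 by methoxy in place of nitro on an aromatic carbon. Among the compounds with values here, no measured step exchanges nitro for methoxy directly. What bears on it is how the nitro arrived: a 2.5-fold lower number from compound 1 to compound 3 (0.40 log units; beyond the scatter) and a 4.7-fold lower number from compound 2 to compound 3 (0.67 log units; beyond the scatter), both modest gains. Taking the nitro away again is therefore expected to cost a modest amount, giving a higher number in this assay for compound 4 than for compound 3, by roughly a 2.0-fold higher number from compound 3 to compound 4 (0.31 log units; beyond the scatter). Compound 4 is thus estimated at 16000 nM, with a likely range of 6000 nM to 40000 nM.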

Compound 4, half-maximal inhibitory concentration: 16700 nM
Estimate against measurement, compound 4: 1.0-fold (0.02 log units) below; the range from low to high includes it.
By their numbers in this assay, from the lowest: compound 3; then compounds 4, 1 and 2 (each within the scatter of the next, the first and the last beyond it).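

In this assay, exchanging nitro for methoxy gives a 2.1-fold higher number from compound 3 to compound 4 (0.33 log units; beyond the scatter) and so shows that the position para to a large group responds to which group sits there. Methoxy in place of hydrogen gives only a 1.2-fold lower number from compound 1 to compound 4 (0.08 log units; within the scatter) and stays within the scatter, so filling this position does not by itself lower the number. Replacing 2-methylphenyl with 4-methoxyphenyl gives a 2.2-fold lower number from compound 2 to compound 4 (0.34 log units; beyond the scatter) as a modest step, but nothing measured here accounts for the difference between nitro and methoxy.

Where a chlorine, a nitrile or an amine at this position would fall relative to nitro and methoxy remains open.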